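From acetyl to propylcarbonyl: compound 3 and compound 4

The source may report more compounds than this note shows. Statements on the series, on what has been measured and on what is new or still open speak of the compounds shown alone.

Measured so far in a functional assay on HepG2 cells (Homo sapiens) for antiproliferative activity, read by MTT assay, with a stated time of 72 h; a higher number here means a weaker inhibitor, a lower number a stronger inhibitor:

Compound 1 (`COc1ccc(NC(=S)Nc2nc(C(=O)NCCCc3ccccc3)cs2)cc1`): 71300 nM
Compound 2 (`O=C(O)c1csc2nc(CN3CCCCC3)c(-c3ccc(Br)cc3)n12`): > 100000 nM (a limit of the assay, not a number)
Compound 3 (`CC(=O)NNC(=O)c1csc2ncc(-c3ccc(C)cc3)n12`): 63600 nM

Going by the values given here, only two true numbers are available in this assay. Compound 1 gives (71300 nM) and compound 3 gives (63600 nM), and these two lie within the scatter of each other. Compound 2 stands at (> 100000 nM), which is a limit and not a number.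

Compound 4 (`CCCC(=O)NNC(=O)c1csc2ncc(-c3ccc(C)cc3)n12`) has not yet been measured. It differs from compound 3 in one place, with ethyl in place of hydrogen on a saturated chain carbon bound to a carbonyl carbon. Read one bond further out, the same difference is acetyl to propylcarbonyl.

Among the compounds with values here, no pair of measured compounds differs in only one place, so the data offer no measured step as a guide. The expectation therefore rests on compound 3 at (63600 nM) alone. In this assay no change beyond the scatter is expected, and the estimated step is (a 1.1-fold lower number from compound 3 to compound 4 (0.03 log units; within the scatter)). Compound 4 is expected to give about (60000 nM), with an estimated range from (25000 nM) to (100000 nM).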

Compound 4, half-maximal inhibitory concentration: 26800 nM
For compound 4 the middle estimate is 2.2-fold (0.35 log units) above the measured one; the measured number falls inside the stated range.
By their numbers in this assay, from the lowest: compound 4; then compounds 3 and 1 (each within the scatter of the next). At a limit, above all of these: compound 2.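

Going by these compounds alone, this is the first step in this assay between two compounds that differ in one place, and it is a real one, though modest: a 2.4-fold lower number from compound 3 to compound 4 (0.38 log units; beyond the scatter). The saturated chain carbon bound to a carbonyl carbon is thus a place where the number responds to a change, since ethyl in place of hydrogen there, which turns acetyl into propylcarbonyl, moves it beyond the scatter with the rest of the structure held fixed. The earlier compounds shown here could not show this, as the values of compound 1 and compound 3 lie within the scatter of each other and those two differ in far more than one place, so they said nothing about this chain.

As far as these compounds go, a single step gives no trend, and it remains open whether a longer chain, a branched chain, or a chain ending in an amine or a carboxylic acid would carry the number further down, leave it where it is, or reverse it. Nothing given here bears on why this change lowers the number.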